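The source may report more compounds than this note shows. Statements on the series, on what has been measured and on what is new or still open speak of the compounds shown alone.

Measured in an ADME assay on the whole organism (Rattus norvegicus), at a dose of 2 mg/kg by the oral route; on this read-out lower numbers stand for lower exposure and higher numbers for higher exposure at the dose given:
- compound 1 `COc1cc(OCc2cccc(-c3cnc(OC)cn3)c2)c2cc(-c3cn4nc(OC)sc4n3)oc2c1`: 722 ng.h/mL
- compound 2 `COc1cc(OCc2cccc(OCc3ccccc3)c2)c2cc(-c3cn4nc(OC)sc4n3)oc2c1`: 339 ng.h/mL

Compound 2 holds the lower of the two numbers in this assay, at 339 ng.h/mL. Compound 3 `COc1cc(OCc2cccc(-c3ccc(C#N)cc3)c2)c2cc(-c3cn4nc(OC)sc4n3)oc2c1` has 4-cyanophenyl in place of benzyloxy on an aromatic carbon.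

Among the compounds with values here, only one measured step bears on this change: a 2.1-fold lower number from compound 1 to compound 2 (0.33 log units; beyond the scatter). It is modest but beyond the scatter, and it brought benzyloxy in place of 5-methoxypyrazin-2-yl. The new change removes benzyloxy again, but the entering group is 4-cyanophenyl rather than 5-methoxypyrazin-2-yl, so that single step is only a loose guide. A modest rise is expected, with an estimated 1.6-fold higher number from compound 2 to compound 3 (0.21 log units; within the scatter). Within the data shown here, no measurement yet shows how 4-cyanophenyl itself behaves. For compound 3 the estimate is 550 ng.h/mL, with an expected range of 230 ng.h/mL to 1300 ng.h/mL.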

Compound 3, area under the concentration-time curve: 610 ng.h/mL
The estimate for compound 3 lay 1.1-fold (0.04 log units) below the measured number; measured number inside the range.
By their numbers in this assay, from the lowest: compounds 2, 3 and 1 (each within the scatter of the next, the first and the last beyond it).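

In this assay, a second directly attached aromatic ring at this position, 4-cyanophenyl, gives a number that cannot be separated from that of 5-methoxypyrazin-2-yl (a 1.2-fold lower number from compound 1 to compound 3 (0.07 log units; within the scatter)). It also cannot be separated from benzyloxy (a 1.8-fold higher number from compound 2 to compound 3 (0.26 log units; within the scatter)), so compound 3 sits within the scatter of both compounds, although those two lie beyond the scatter of each other, and the series does not yet resolve into distinct levels for these three groups. No measurement is available that could explain these exposure numbers.

Going by these compounds, it remains open whether the nitrile contributes anything, which an unsubstituted phenyl would test. On these data alone, it also remains open whether a morpholine or a carboxylic acid on this carbon would leave exposure in the same range.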